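From a Carbonyl Side Chain to 2-Hydroxyethyl

A few compounds are considered here, and "the series" means these few. Any claim that something is new, unique, unknown or untested is made for them only; others in the source may bear on it.

Within the data shown here, in a functional assay on DU-145 cells (Homo sapiens) for cytotoxicity, read by MTT assay (a higher number here means a weaker inhibitor, a lower number a stronger inhibitor), compound 1 (`CC(C)=CC[C@@H](OC[C@H](C)O)C1=CC(=O)c2c(O)ccc(O)c2C1=O`) gives 24500 nM and compound 2 (`CC(C)=CC[C@@H](OC(=O)CC(C)(O)C(C)C)C1=CC(=O)c2c(O)ccc(O)c2C1=O`) gives 16900 nM, which places compound 2 within the scatter of the only other measured number. Compound 3 (`CC(C)=CC[C@@H](OCCO)C1=CC(=O)c2c(O)ccc(O)c2C1=O`) differs from compound 2 as follows: 2-hydroxyethyl in place of (2-hydroxy-2,3-dimethylbutyl)carbonyl on an oxygen on a saturated carbon. Among the measured compounds shown here, only one measured step bears on this change, and it lies at the same place: a 1.4-fold lower number from compound 1 to compound 2 (0.16 log units; within the scatter), with (2-hydroxy-2,3-dimethylbutyl)carbonyl in place of 2-hydroxypropyl. That step stays within the scatter, but 2-hydroxyethyl itself has not been measured, so this single step offers limited support. No step beyond the scatter is therefore expected in this assay. The expected change is a 1.2-fold higher number from compound 2 to compound 3 (0.07 log units; within the scatter), with no firm direction. Compound 3 is estimated at 20000 nM, with an expected range of 10000 nM to 40000 nM.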

Compound 3, half-maximal inhibitory concentration: 9900 nM
For compound 3 the middle estimate is 2.0-fold (0.31 log units) above the measured one; the measured number lies below the stated range.
By their numbers in this assay, from the lowest: compounds 3, 2 and 1 (each within the scatter of the next, the first and the last beyond it).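

At this oxygen on a saturated carbon, the large (2-hydroxy-2,3-dimethylbutyl)carbonyl group, with its 9 heavy atoms, can give way to 2-hydroxyethyl, with 3, without a change beyond the scatter in this assay: the result is a 1.7-fold lower number from compound 2 to compound 3 (0.23 log units; within the scatter). Among the earlier compounds nothing had moved beyond the scatter, whereas hydrogen in place of methyl on the saturated chain carbon gives a 2.5-fold lower number from compound 1 to compound 3 (0.39 log units; beyond the scatter), so this small change produces the only modest difference seen so far at this position. Nothing measured here explains either step.

On these data alone, all three side chains carry a hydroxyl, so whether that group is needed remains open. It is also unknown how a longer chain such as 3-hydroxypropyl, an amine or a carboxylic acid would fare on this oxygen.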